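The source may report more compounds than this note shows. Statements on the series, on what has been measured and on what is new or still open speak of the compounds shown alone.

Working notes on the series. Of the compounds shown here, three built on a shared core have so far been measured in a functional assay on T47D cells (Homo sapiens) for cytotoxicity, read by MTT assay, with a stated time of 48 h; a higher number here means a weaker inhibitor, a lower number a stronger inhibitor. Compound 1 `Fc1ccc(NC(=S)N/N=C\c2ccnc3ccccc23)cc1` gives 1070 nM. Compound 2 `S=C(N/N=C\c1ccnc2ccccc12)Nc1ccc(Cl)cc1` gives 1270 nM. Compound 3 `S=C(N/N=C\c1ccnc2ccccc12)Nc1cccc2ccccc12` gives 1210 nM. Compound 2 carries the highest of the three numbers, yet its gap to compound 3, the nearest, and to compound 1, the furthest, both sit within the scatter, so nothing separates these three on the values in hand.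

Going by the values given here, only one single-point step has been measured: chloro in place of fluoro on an aromatic carbon, which reads a 1.2-fold higher number from compound 1 to compound 2 (0.07 log units; within the scatter) and stays within the scatter.

Compound 4 `CCc1ccc(NC(=S)N/N=C\c2ccnc3ccccc23)cc1` departs from compound 2 at that same position: ethyl in place of chloro on an aromatic carbon. Among the compounds with values here, the one step that bears on this change is the exchange of one small group for another at this carbon between compound 1 and compound 2, and it moved the number by almost nothing. Within the data shown here, with no measured step at this position reaching beyond the scatter, no step beyond the scatter is expected here either, in either direction. For compound 4 the step of a 1.1-fold lower number from compound 2 to compound 4 (0.02 log units; within the scatter) is therefore estimated to stay within the scatter. Compound 4 is expected to give 1200 nM, with a range from 600 nM to 2400 nM.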

Compound 4, half-maximal inhibitory concentration: 1280 nM
Beside the measured number, compound 4's estimate is 1.1-fold (0.03 log units) below it; low and high end bracket the measured number.
By their numbers in this assay, from the lowest: compounds 1, 3, 2 and 4 (each within the scatter of the next).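

Ethyl in place of chloro reads a 1.0-fold higher number from compound 2 to compound 4 (0.00 log units; within the scatter) in this assay, and ethyl in place of fluoro reads a 1.2-fold higher number from compound 1 to compound 4 (0.08 log units; within the scatter) on the same scale. Going by these compounds alone, until now, the only step at this carbon was an exchange of one halogen for another; these two steps show that a two-carbon alkyl group with no halogen also stays within the scatter, whichever halogen it replaces. Fluoro, chloro and ethyl are therefore not separated at this carbon on the values in hand, and no information bears on why the number stays within the scatter across these groups.

On these data alone, whether an amine, a carboxylic acid, a methoxy group or a longer chain at this carbon would also stay within the scatter remains open, so the limits of this tolerance are not yet defined. The compounds shown also leave open what a change on the shared core itself would do, since every step read so far lies on the outer aromatic ring.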